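The compounds below may be only part of what the source reports. "The series", "measured", "known", "first", "only" and "open" are said of these compounds alone.

Measured in an in vitro ADME assay on microsomes from liver (Homo sapiens) for metabolic stability (a higher number here means faster removal of the compound, a lower number slower removal), each entry a limit of the assay and not a number:
- compound 1 `Cc1cnc(NC(=O)c2cc(Oc3ccc(S(C)(=O)=O)cc3)c3cn(C)nc3c2)cn1`: < 8 mL/min/kg
- compound 2 `CCS(=O)(=O)c1ccc(Oc2cc(C(=O)Nc3cnc(C)cn3)cc3nn(C)cc23)cc1`: < 8 mL/min/kg
- compound 3 `CCn1cc2c(Oc3ccc(S(C)(=O)=O)cc3)cc(C(=O)Nc3cnc(C)cn3)cc2n1`: < 8 mL/min/kg

Compound 3 stands only at a limit, < 8 mL/min/kg. Among the compounds with values here, the series so far offers only (the limit of < 8 mL/min/kg in this assay, at which 3 of the 3 values shown sit), so no ranking can be read from it.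

The next compound to be measured is compound 4 `Cc1cnc(NC(=O)c2cc(Oc3ccc(S(C)(=O)=O)cc3)c3cn(CCO)nc3c2)cn1`, and its difference from compound 3 is hydroxy in place of hydrogen on a saturated chain carbon, two bonds along the chain from an aromatic nitrogen. Cut one bond further out, the same difference reads ethyl to 2-hydroxyethyl.

The measured step that bears most directly on this is a step that the two limits leave unreadable from compound 1 to compound 3, with methyl in place of hydrogen on a saturated chain carbon bound to an aromatic nitrogen. The other is a step that the two limits leave unreadable from compound 1 to compound 2, with methyl in place of hydrogen on a saturated chain carbon bound to a sulfonyl sulfur. Within the data shown here, neither gives a size, and no measured compound carries a hydroxy. No change beyond the scatter and no particular direction is therefore expected in this assay. The expected step is a step that the limit leaves unreadable from compound 3 to compound 4. Compound 4 is estimated at 7 mL/min/kg, with an expected range of 4 mL/min/kg to 13 mL/min/kg.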

Compound 4, clearance: < 8.9 mL/min/kg
Compound 4 was reported as a limit; the forecaster's own chance of this, stated with the estimate: 70%; the middle value is on the limit's open side.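

In this assay compound 4 gives only a limit, < 8.9 mL/min/kg. The steps to compound 4 from compound 1 and from compound 3 cannot be read: all three entries are limits. The compounds shown leave open how fast each is actually removed in this assay, and whether ethyl to 2-hydroxyethyl changes clearance at all.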